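Swapping a furan carbonyl for pyrimidine on the piperazine

The compounds below may be only part of what the source reports. "The series", "measured", "known", "first", "only" and "open" are said of these compounds alone.

Measured compounds:
Compound 1 `COc1ccccc1-c1ccc(N2CC(N3CCN(C(=O)c4ccco4)CC3)CC2=O)cc1` gives 30 nM in an assay on isolated protein for inhibition of Monoglyceride lipase (Mus musculus), with a stated time of 30 min; on this read-out lower numbers stand for stronger inhibition and higher numbers for weaker inhibition.
Compound 2 `O=C(c1ccco1)N1CCN(C2CC(=O)N(c3ccc(-c4ccccc4F)cc3)C2)CC1` gives 37 nM.
Compound 3 `O=C(c1ccco1)N1CCN(C2CC(=O)N(c3ccc(-c4ccc(F)nc4)cc3)C2)CC1` gives 127 nM.

Compound 1 has the lowest number of the three; compound 2 sits within the scatter of it (a 1.2-fold higher number from compound 1 to compound 2 (0.09 log units; within the scatter)), while compound 3 lies further off (a 4.2-fold higher number from compound 1 to compound 3 (0.63 log units; beyond the scatter)). Compound 4 `COc1ccccc1-c1ccc(N2CC(N3CCN(c4ncccn4)CC3)CC2=O)cc1` keeps the shared core of compound 1 and changes only the group on the piperazine: pyrimidin-2-yl in place of (furan-2-yl)carbonyl on an amine nitrogen in a ring. The amide carbonyl linking the furan is lost, and an aromatic ring becomes directly attached to the ring nitrogen.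

Within the data shown here, none of the measured steps touches this part of the molecule. Each of them varies the outer aromatic ring: the within-scatter step a 1.2-fold higher number from compound 1 to compound 2 (0.09 log units; within the scatter), and the modest steps of a 4.2-fold higher number from compound 1 to compound 3 (0.63 log units; beyond the scatter) and a 3.4-fold higher number from compound 2 to compound 3 (0.54 log units; beyond the scatter). They show that the piperazine amide side is carried unchanged through all three compounds, so they give no direct guide to what happens when the amide itself is replaced. The change removes a feature shared by every measured compound. The expectation is uncertain and leans toward a weaker result.

Compound 4 is therefore estimated at 150 nM, with a range from 30 nM to 1000 nM, which means an expected step of a 5.0-fold higher number from compound 1 to compound 4 (0.70 log units; beyond the scatter) in this assay.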

Compound 4, half-maximal inhibitory concentration: 72 nM
The estimate for compound 4 lay 2.1-fold (0.32 log units) above the measured number; the measured number falls inside the stated range.
By their numbers in this assay, from the lowest: compounds 1, 2, 4 and 3 (each within the scatter of the next, the first and the last beyond it).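

In this assay, placing pyrimidin-2-yl instead of (furan-2-yl)carbonyl on the amine nitrogen in the ring gives a 2.4-fold higher number from compound 1 to compound 4 (0.38 log units; beyond the scatter). Among these compounds, this is the first reading at this position, since every earlier compound carries the same (furan-2-yl)carbonyl group: the change costs a modest amount of inhibition, but compound 4 still gives 72 nM, so in this one pair neither the carbonyl nor the furan is essential for inhibition in this range. Among the compounds shown here, no measurement in hand explains why the number rises, and the single step cannot say how much of it belongs to the lost carbonyl and how much to the new ring.

Two things change at once here, so a pyrimidine-2-carbonyl group, which would keep the carbonyl and change only the ring, or a furan-2-yl group set directly on the nitrogen, which would do the reverse, would be needed to separate them. Going by these compounds, it also remains open whether pyrimidin-2-yl behaves the same way alongside the 2-fluorophenyl or 6-fluoropyridin-3-yl outer rings, and how a simple acetyl group or a benzoyl group would compare at this nitrogen.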